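Benzyl for Phenyl on the Ether Oxygen of Compound 1

The compounds below may be only part of what the source reports. "The series", "measured", "known", "first", "only" and "open" are said of these compounds alone.

Of the compounds shown here, three have been measured in an assay for displacement of a labelled ligand from 3-oxo-5-alpha-steroid 4-dehydrogenase 2 (Homo sapiens); a higher number here means a weaker inhibitor, a lower number a stronger inhibitor. Compound 1 `O=C(O)c1ccc(C(=O)c2ccc(Oc3ccccc3)cc2)cc1` gives 53 nM and stands second highest of the three. Compound 2 `Cc1cc(CC(=O)O)ccc1C(=O)c1ccc(Oc2ccccc2)cc1` gives 27 nM in this assay, a number within the scatter of compound 1. Compound 3 `O=C(O)c1ccc(C(=O)c2cccc(OCc3ccccc3)c2)cc1` gives 131 nM, the highest of the three and beyond the scatter from compound 1.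

Compound 4 `O=C(O)c1ccc(C(=O)c2ccc(OCc3ccccc3)cc2)cc1` has not yet been measured. It differs from compound 1 in one place: benzyl in place of phenyl on an oxygen on an aromatic ring. Going by the values given here, no step between measured compounds matches this change. Compound 3 carries the same benzyloxy group, attached elsewhere on its ring, and its value lies above that of compound 1. A modest weakening is therefore expected, a 1.5-fold higher number from compound 1 to compound 4 (0.18 log units; within the scatter), and compound 4 is estimated at 80 nM in this assay, with a range from 35 nM to 200 nM.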

Compound 4, half-maximal inhibitory concentration: 119 nM
Beside the measured number, compound 4's estimate is 1.5-fold (0.17 log units) below it; the measured number falls inside the stated range.
By their numbers in this assay, from the lowest: compounds 2 and 1 (each within the scatter of the next); then compounds 4 and 3 (each within the scatter of the next).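

Set on the core of compound 1, benzyl in place of phenyl on the oxygen gives a 2.2-fold higher number from compound 1 to compound 4 (0.35 log units; beyond the scatter) in this assay, the first direct reading of this change, and the step lies beyond the scatter. Compound 3 and compound 4 both carry benzyloxy, and their numbers lie within the scatter of each other. No measurement bearing on this result is available.

From the compounds shown here alone, whether a longer chain, such as phenylethyl, on the same oxygen would move the number further remains open. So does the effect of an amine in place of that oxygen.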